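Benzothiazolyl pyrazole carboxamides: methoxy to methyl on the benzothiazole

This account rests on a few compounds, and the source may have more. Where it says the series, first, only, none or still open, it means among the compounds named here.

Measured so far:
compound 1 `Cc1ccc2nc(NC(=O)c3cn(-c4ccccc4)nc3-c3ccccc3)sc2c1`, 26500 nM
compound 2 `Cc1ccc2nc(NC(=O)c3cn(-c4ccccc4)nc3-c3ccc(F)cc3)sc2c1`, 24600 nM
compound 3 `COc1ccc(-c2nn(-c3ccccc3)cc2C(=O)Nc2nc3ccc(OC)cc3s2)cc1`, 18900 nM

In a functional assay on A549 cells (Homo sapiens) for cytotoxicity, read by MTT assay, with a stated time of 72 h (a lower number here means a stronger inhibitor, a higher number a weaker inhibitor), all three compounds sit close together. Compound 3 is the one nearest the low end of the three, but compound 2 and compound 1 both lie within the scatter of it, so no order among them can be read from these numbers. Among the measured compounds shown here, the only single-point step measured so far is a 1.1-fold lower number from compound 1 to compound 2 (0.03 log units; within the scatter), on the phenyl ring of the pyrazole, and it falls within the scatter. Compound 1 and compound 3 differ in two places, so their two values show only that they are alike.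

Compound 4 `COc1ccc(-c2nn(-c3ccccc3)cc2C(=O)Nc2nc3ccc(C)cc3s2)cc1` differs from compound 3 by methyl in place of methoxy on an aromatic carbon. For the measured compounds named here, no measured step touches this position, so nothing here speaks for a change beyond the scatter in this assay. Compound 4 is therefore expected near compound 3, at an estimated 22000 nM with a range of 11000 nM to 45000 nM, an expected step of a 1.2-fold higher number from compound 3 to compound 4 (0.07 log units; within the scatter).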

Compound 4, half-maximal inhibitory concentration: 27700 nM
For compound 4 the middle estimate is 1.3-fold (0.10 log units) below the measured one, and the stated range covers the measured number.
By their numbers in this assay, from the lowest: compounds 3, 2, 1 and 4 (each within the scatter of the next).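

In this assay, among the compounds shown here, the change from 6-methoxy-1,3-benzothiazol-2-yl to 6-methyl-1,3-benzothiazol-2-yl gives a 1.5-fold higher number from compound 3 to compound 4 (0.17 log units; within the scatter) as the first measured step at this position, and that step stays within the scatter. With methyl held on the benzothiazole, compound 4 also allows two readings at the aromatic carbon where compound 1 and compound 2 differ: a 1.0-fold higher number from compound 1 to compound 4 (0.02 log units; within the scatter) and a 1.1-fold higher number from compound 2 to compound 4 (0.05 log units; within the scatter) both lie within the scatter, so hydrogen, fluoro and methoxy are not told apart there. No evidence on the cause of these values is at hand.

All six pairs among the four compounds lie within the scatter, so no substituent shown here separates one compound from another. Going by these compounds, whether an amine, a carboxylic acid or a longer chain in place of the methyl on the benzothiazole would give a step beyond the scatter remains open.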